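Replacing 1H-indazol-5-yl with (1H-indol-5-yl)methyl: an open step

This account rests on a few compounds, and the source may have more. Where it says the series, first, only, none or still open, it means among the compounds named here.

In a functional assay on K562 cells (Homo sapiens) for inhibition, read by trypan blue exclusion, with a stated time of 72 h (a lower number here means a stronger inhibitor, a higher number a weaker inhibitor), compound 1 `Cn1c(=O)c(S(=O)(=O)c2ccccc2)cc2cnc(Nc3ccc4ncccc4c3)nc21` gives 100000 nM. Compound 2 `Cn1c(=O)c(S(=O)(=O)c2ccc(F)cc2F)cc2cnc(Nc3ccc4[nH]ncc4c3)nc21` gives 50000 nM, which lies within the scatter of the number for compound 1. Compound 3 `Cn1c(=O)c(S(=O)(=O)c2ccc(F)cc2)cc2cnc(Nc3ccc4[nH]ncc4c3)nc21` gives 10000 nM, so compound 2 stands well above it. The structural change under consideration leads to compound 4 `Cn1c(=O)c(S(=O)(=O)c2ccc(F)cc2F)cc2cnc(NCc3ccc4[nH]ccc4c3)nc21`, which carries (1H-indol-5-yl)methyl in place of 1H-indazol-5-yl on a nitrogen on an aromatic ring. Among the measured compounds shown here, only one measured step bears on this, and only indirectly. It is a 5.0-fold lower number from compound 2 to compound 3 (0.70 log units; beyond the scatter), a modest change that replaces fluoro with hydrogen on an aromatic carbon and leaves the group on that nitrogen untouched. For the measured compounds named here, no measured step alters that group, so the data set neither a size nor a direction for this change. No shift beyond the scatter is therefore expected in this assay, and the expected change is a 1.7-fold lower number from compound 2 to compound 4 (0.22 log units; within the scatter). For compound 4 the estimated value is 30000 nM, with an expected range of 4000 nM to 100000 nM.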

Compound 4, half-maximal inhibitory concentration: 75000 nM
Estimate against measurement, compound 4: 2.5-fold (0.40 log units) below; the measured number falls inside the stated range.
By their numbers in this assay, from the lowest: compound 3; then compounds 2, 4 and 1 (each within the scatter of the next).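

In this assay, among the compounds shown here, this is the first step to alter the group on that nitrogen, and it reads a 1.5-fold higher number from compound 2 to compound 4 (0.18 log units; within the scatter), so exchanging 1H-indazol-5-yl for (1H-indol-5-yl)methyl gives no change that can be told from the scatter. The only step shown beyond the scatter remains a 5.0-fold lower number from compound 2 to compound 3 (0.70 log units; beyond the scatter), which leaves that nitrogen's group untouched. Nothing available accounts for this result.

Open, from the compounds shown here alone, is how the number would respond to 1H-indol-5-yl or (1H-indazol-5-yl)methyl on that nitrogen, which would separate the change of ring from the inserted chain, and whether the same exchange reads alike with hydrogen in place of fluoro, as in compound 3. Also open, going by these compounds, is what a longer chain or an amine on this group would do.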